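Three measured analogues, a fourth awaiting its number

A few compounds are considered here, and "the series" means these few. Any claim that something is new, unique, unknown or untested is made for them only; others in the source may bear on it.

Compound 1, `COc1cc(OC)c(OC)cc1/C=C/C(=O)c1ccc(C)cc1`, gives 42200 nM in a functional assay on HeLa cells (Homo sapiens) for inhibition, read by MTT assay, with a stated time of 72 h; on this read-out higher numbers stand for weaker inhibition and lower numbers for stronger inhibition.
Compound 2, `COc1cc(OC)c(OC)cc1/C=C/C(=O)c1cc(Cl)ccc1O`, gives only a limit of the assay, > 150000 nM.
Compound 3, `COc1cc(OC)c(OC)cc1/C=C/C(=O)c1cc(O)ccc1O`, likewise gives only a limit, > 150000 nM.

Compound 3 therefore stands at the edge of what this assay reports; its value is a limit and not a number, and compound 2 sits at the same limit, (the limit of > 150000 nM in this assay, at which 2 of the 3 values shown sit). Only compound 1 has a measured number.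

The piece now turns to compound 4, `COc1cc(OC)c(OC)cc1/C=C/C(=O)c1ccc(F)cc1`, which is not yet measured. The change from compound 3 is 4-fluorophenyl in place of 2,5-dihydroxyphenyl on a carbonyl carbon.

Among the compounds with values here, the steps that bear on it run the other way. Putting a hydroxy-bearing ring in place of 4-methylphenyl gave an at least 3.5-fold higher number from compound 1 to compound 2 (0.55 log units; beyond the scatter) and an at least 3.5-fold higher number from compound 1 to compound 3 (0.55 log units; beyond the scatter), while the hydroxy in place of chloro gave a step that the two limits leave unreadable from compound 2 to compound 3. Compound 4 carries a 4-fluorophenyl, a ring without the hydroxy groups, which resembles the 4-methylphenyl of compound 1 more than the ring of compound 3. So the number for compound 4 is expected to fall back toward that of compound 1, an expected step of an at least 3.7-fold lower number from compound 3 to compound 4 (0.57 log units; beyond the scatter).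

The estimate for compound 4 in this assay is 40000 nM, expected between 15000 nM and 120000 nM.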

Compound 4, half-maximal inhibitory concentration: 28600 nM
Compound 4: the middle estimate sits 1.4-fold (0.15 log units) above what was measured; the measured number falls inside the stated range.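

Within the data shown here, at this place on the carbonyl carbon, the earlier compounds showed only that the two hydroxy-bearing rings brought the read-out to the limit, and compound 4 now shows that a second ring without hydroxy gives a measured number again in this assay, with an at least 5.2-fold lower number from compound 3 to compound 4 (0.71 log units; beyond the scatter) and an at least 5.2-fold lower number from compound 2 to compound 4 (0.71 log units; beyond the scatter). The two rings without hydroxy, 4-fluorophenyl and 4-methylphenyl, cannot be told apart here, since fluoro in place of methyl gives a 1.5-fold lower number from compound 1 to compound 4 (0.17 log units; within the scatter). The two steps from the hydroxy-bearing rings can be read only as bounds, because neither compound 2 nor compound 3 gives a number: the limit of > 150000 nM in this assay, at which 2 of the 4 values shown sit.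

The compounds shown leave open how much of the loss belongs to the hydroxy itself, since both rings at the limit carry one and the step between compound 2 and compound 3 cannot be read. They also leave open whether an amine or a carboxylic acid on this ring would stay with the rings that give a number or join those at the limit.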